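A few compounds are considered here, and "the series" means these few. Any claim that something is new, unique, unknown or untested is made for them only; others in the source may bear on it.

Measured compounds, cytotoxicity read-out:

- compound 1, `O=C(/C=C/c1ccc2c(c1)B(O)OC2)c1ccco1`: > 10 ug/mL, a limit of the assay rather than a number
- compound 2, `Nc1ccc(C(=O)/C=C/c2ccc3c(c2)B(O)OC3)cc1`: > 10 ug/mL, likewise a limit
- compound 3, `Cn1cccc1C(=O)/C=C/c1ccc2c(c1)B(O)OC2`: > 10 ug/mL, likewise a limit

All three values come from an ADME assay on L929 cells (Mus musculus) for cytotoxicity, read by resazurin assay, with a stated time of 72 h; on this read-out lower numbers stand for stronger inhibition and higher numbers for weaker inhibition. Compound 2 therefore stands at the assay limit, as do the two other measured compounds, which is what the limit of > 10 ug/mL in this assay, at which 3 of the 3 values shown sit, records. The steps between them, a step that the two limits leave unreadable from compound 1 to compound 2, a step that the two limits leave unreadable from compound 1 to compound 3 and a step that the two limits leave unreadable from compound 2 to compound 3, cannot be read in size or direction. Every value involved is a limit.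

Compound 4, `CC(=O)Nc1ccc(C(=O)/C=C/c2ccc3c(c2)B(O)OC3)cc1`, differs from compound 2 by acetyl in place of hydrogen on a nitrogen on an aromatic ring. Among the compounds with values here, no measured step bears on this change: the only step that touches this nitrogen-bearing group, from compound 1 to compound 2, is itself unreadable. What the three measurements do show is that three different groups on the carbonyl carbon of the shared core all leave the value at the limit.

Compound 4 is expected to sit at the limit as well, with an estimate of 15 ug/mL, between 7 ug/mL and 40 ug/mL. The step that the limit leaves unreadable from compound 2 to compound 4 is expected to be none beyond the scatter.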

Compound 4, half-maximal inhibitory concentration: > 10 ug/mL
Compound 4: only a limit was reported; the forecaster's own chance of this, stated with the estimate: 85%; the middle value lies beyond the limit too.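

In this assay compound 4 gives > 10 ug/mL, a limit and not a number. The step from compound 2 to compound 4 therefore cannot be read. The compounds shown leave open whether acetyl in place of hydrogen on this nitrogen changes cytotoxicity at all, and where any of the four compounds would fall as an actual number.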